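Pyrimidinyl-amino quinolizinone series: liver microsome stability notes

The compounds below may be only part of what the source reports. "The series", "measured", "known", "first", "only" and "open" are said of these compounds alone.

Measured compounds in an ADME assay on microsomes from liver (Rattus norvegicus), read by LC-MS, using NADPH, with a stated time of 30 min, tested at 1 uM; a higher number here means that more of the compound is left, a lower number that less of the compound is left:
compound 1 `C[C@H](Nc1ncnc(N)c1C#N)c1cc(=O)n2cc(F)ccc2c1-c1cc(F)cc(F)c1`, 60%
compound 2 `C[C@H](Nc1nc(N)nc(N)c1C#N)c1cc(=O)n2cc(F)ccc2c1-c1cc(F)cc(F)c1`, 87%
compound 3 `C[C@H](Nc1ncnc(N)c1C#N)c1c(C2CC2)c(=O)n2cc(F)ccc2c1-c1ccc(F)cc1`, 1%

Compound 1 and compound 2 share a core and differ by one change, (amino in place of hydrogen on an aromatic carbon). In this assay that change gives a number 27 percentage points higher from compound 1 to compound 2 (beyond the scatter). Compound 3 carries a different core; how the core of compound 3 differs from the core of compound 1 is not broken down here. In this assay compound 3 gives the lowest number of the three measured compounds, with compound 1 the nearest of the other two and compound 2 the furthest, both steps beyond the scatter.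

Compound 4 `C[C@H](Nc1nc(N)nc(N)c1C#N)c1c(C2CC2)c(=O)n2cc(F)ccc2c1-c1ccc(F)cc1` is not yet measured in this assay. It stands to compound 3 as compound 2 stands to compound 1: the change is amino in place of hydrogen on an aromatic carbon, and the place lines of the two changes read the same word for word, so it is the same change on a different core.

Within the data shown here, the expectation for compound 4 rests on the one measured instance of this change, from compound 1 to compound 2 a number 27 percentage points higher from compound 1 to compound 2 (beyond the scatter), applied to the very low starting number of compound 3 1%. The step from compound 3 to compound 4 is expected at a number 9 percentage points higher from compound 3 to compound 4 (within the scatter), smaller than the earlier one, since a number near the bottom of the scale leaves less room for the same gain to show and the core of compound 3 is not the core on which the change was measured. Compound 4 is therefore estimated at 10%, with a range from 1% to 35% expected.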

Compound 4, percent of the compound remaining: 35%
Beside the measured number, compound 4's estimate is 25 percentage points below it; the measured number falls inside the stated range.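

In this assay, replacing 6-amino-5-cyanopyrimidin-4-yl with 2,6-diamino-5-cyanopyrimidin-4-yl gives a number 34 percentage points higher from compound 3 to compound 4 (beyond the scatter), so the gain measured on the core of compound 1 also appears on the core of compound 3, even from the very low starting point of compound 3 at 1%. The two steps cannot be told apart in size, and on these data the change carries over between the two cores as a similar gain in percentage points: the same change on two cores in this assay, a number 27 percentage points higher (beyond the scatter) from compound 1 to compound 2 and a number 34 percentage points higher (beyond the scatter) from compound 3 to compound 4, 7 percentage points apart, within the scatter of two such steps. Among these compounds, this rests on only two matched pairs, so it supports a transfer between these two cores but establishes no rule for other cores, and it does not show why the amino group raises the amount of compound remaining.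

The compounds shown leave open whether a different group in the same place on the pyrimidine ring, such as methylamino, methyl or hydroxyl, would give a step of similar size. They also leave open which of the differences between the two cores accounts for the gap between compound 1 and compound 3, since those two compounds differ in more than one place.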